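This account rests on a few compounds, and the source may have more. Where it says the series, first, only, none or still open, it means among the compounds named here.

Measured compounds:

Compound 1 `Fc1cccc(C#Cc2nc3c(s2)CN(C2CCC2)CC3)c1` — in an assay on HEK293 cells for negative allosteric modulation of metabotropic glutamate receptor 5 (Homo sapiens), read by FLIPR, with a stated time of 1 h (on this read-out lower numbers stand for stronger inhibition and higher numbers for weaker inhibition), compound 1 gives 200 nM.
Compound 2 `CCC(=O)N1CCc2nc(C#Cc3ccccc3)sc2C1` — in this assay compound 2 gives 38 nM.

Of the two numbers at hand, compound 2 holds the lower one; its nearest neighbour is compound 1, whose number is higher by a margin beyond the usual scatter. Within the data shown here, compound 1 and compound 2 differ in more than one place, so their two values show only that the pair spans a real gap, not which part of the structure accounts for it.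

Compound 3 `O=C(C1CCC(F)(F)CC1)N1CCc2nc(C#Cc3ccccc3)sc2C1` is not yet measured. It differs from compound 2 at a single position: 4,4-difluorocyclohexyl in place of ethyl on a carbonyl carbon. The group that enters is larger and carries a ring; the group that leaves is a short chain. Among the measured compounds shown here, no measured pair in this set isolates a change of this kind at the carbonyl carbon, so there is no step to lean on. The expectation for compound 3 in this assay is therefore set close to compound 2, allowing a wider spread in either direction: the step from compound 2 to compound 3 is estimated at a 1.1-fold higher number from compound 2 to compound 3 (0.02 log units; within the scatter), which is no step beyond the scatter. Compound 3 is expected to give 40 nM, within the range 12 nM to 130 nM.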

Compound 3, half-maximal inhibitory concentration: > 10000 nM
Compound 3: only a limit was reported (the forecaster's own chance of this, stated with the estimate: 3%); at least 250-fold (2.39 log units) between middle value and limit.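

Among these compounds, this is the first pair in the set that isolates a single change at the carbonyl carbon, and it shows that this position is far from indifferent to the group it carries: 4,4-difluorocyclohexyl in place of ethyl gives an at least 260-fold higher number from compound 2 to compound 3 (2.42 log units; beyond the scatter) in this assay. The rest of the structure is the same in both compounds, so this whole gap belongs to that one exchange, unlike the gap between compound 1 and compound 2, which could not be assigned to any one part. The figure for compound 3 is a limit and not a number, so the step has a lower bound but no known size: the limit of > 10000 nM in this assay, at which 1 of the 3 values shown sits.

A single step cannot separate the contributions of the ring, the two fluorine atoms and the larger count of heavy atoms, so it gives no reason for the loss. Going by these compounds, how plain cyclohexyl, cyclopropyl or a longer chain such as butyl would read on the same carbonyl carbon remains open, and with it the point between ethyl and 4,4-difluorocyclohexyl at which inhibition falls away.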